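Aryl Ether Variation Held at a Limit of Inhibition

The source may report more compounds than this note shows. Statements on the series, on what has been measured and on what is new or still open speak of the compounds shown alone.

Compound 1, `NC1=NC2(CCOCC2)N(OCCCOc2ccccc2)C(N)=N1`: in an assay on isolated protein for inhibition of Dihydrofolate reductase (Homo sapiens), read by spectrophotometry, using NADPH, with stated times of 5 s and 6 min, tested at 5 uM (a higher number here means a stronger effect of the compound at the concentration tested, a lower number a weaker effect), compound 1 gives > 90%, which is a limit of the assay, not a number.
Compound 2, `NC1=NC2(CCOCC2)N(OCCCOc2ccc(Cl)cc2)C(N)=N1`: in this assay compound 2 gives > 90%, again a limit of the assay.
Compound 3, `NC1=NC2(CCOCC2)N(OCCCOc2ccc(F)cc2)C(N)=N1`: in this assay compound 3 gives > 90%, also a limit of the assay.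

Compound 3 therefore stands at the limit rather than at a measured number, and it shares this position with the other two compounds, as shown by the limit of > 90% in this assay, at which 3 of the 3 values shown sit. The steps among the three, a step that the two limits leave unreadable from compound 1 to compound 2, a step that the two limits leave unreadable from compound 1 to compound 3 and a step that the two limits leave unreadable from compound 2 to compound 3, have no readable size because both ends of each pair sit at the limit of > 90% in this assay, at which 3 of the 3 values shown sit.

Compound 4, `Cc1cc(C)cc(OCCCON2C(N)=NC(N)=NC23CCOCC3)c1`, has not yet been measured. It differs from compound 3 in one place: 3,5-dimethylphenyl in place of 4-fluorophenyl on an oxygen on a saturated carbon. The three measured steps bear on this change only in that every variation of the aromatic ring so far left the read-out at the limit; none of them gives a size. The step that the limit leaves unreadable from compound 3 to compound 4 is thus expected to be none beyond the scatter. Compound 4 is estimated at 93%, within 82% to 100%, and most likely it will again be reported only as a limit.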

Compound 4, a percentage reported as inhibition, at one concentration (the size of the read-out at that concentration, not a potency): 84.3%
Compound 4: middle estimate off by 8.7 percentage points, on the high side, and the stated range covers the measured number.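

Compound 4 is the first compound here to carry a number rather than a limit, so at this place, on an oxygen on a saturated carbon, a change of the aromatic group can now be given at least a lower bound: the limit of > 90% in this assay, at which 3 of the 4 values shown sit.

In this assay, 3,5-dimethylphenyl in place of 4-fluorophenyl gives a number at least 5.7 percentage points lower from compound 3 to compound 4 (that floor lies within the scatter), in place of 4-chlorophenyl it gives a number at least 5.7 percentage points lower from compound 2 to compound 4 (that floor lies within the scatter), and in place of phenyl it gives a number at least 5.7 percentage points lower from compound 1 to compound 4 (that floor lies within the scatter). Each of these is only a floor, so the series does not yet show a real difference between 3,5-dimethylphenyl and the other three aromatic groups, though it also no longer shows every aromatic group sitting at the limit.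

From the compounds shown here alone, how far compound 1, compound 2 and compound 3 truly lie from compound 4 stays open, and a test at a lower concentration would be needed to settle it. Also open, going by these compounds, is how the read-out would respond to an amine or a carboxylic acid on the aromatic ring, or to a longer chain in place of the saturated chain that carries the aryl ether.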